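Hydroxy in place of hydrogen on the outer ring: compound 4

The source may report more compounds than this note shows. Statements on the series, on what has been measured and on what is new or still open speak of the compounds shown alone.

Compound 1 `COc1cc(-c2ccccc2)cc(O)c1O`: in a functional assay on HCT-15 cells (Homo sapiens) for cytotoxicity, read by sulforhodamine B assay (a higher number here means a weaker inhibitor, a lower number a stronger inhibitor), compound 1 gives > 10000 nM, a limit of the assay.
Compound 2 `COc1cc(O)cc(-c2ccccc2)c1`: in this assay compound 2 gives > 10000 nM, also a limit.
Compound 3 `COc1cc(OC)cc(-c2ccccc2)c1`: in this assay compound 3 gives > 10000 nM, again a limit.

The measured steps are a step that the two limits leave unreadable from compound 2 to compound 1 and a step that the two limits leave unreadable from compound 2 to compound 3, both unreadable because of the limit of > 10000 nM in this assay, at which 3 of the 3 values shown sit. The two cores differ by methyl in place of hydrogen on an oxygen on an aromatic ring. Compound 4 `COc1cc(OC)cc(-c2ccc(O)cc2)c1` is not yet measured; its change from compound 3 is hydroxy in place of hydrogen on an aromatic carbon, the same kind of change as hydroxy in place of hydrogen on an aromatic carbon, though the place differs: para to a large group in the new pair, ortho to a hydroxy group, ortho to a methoxy group and para to a group of 6 heavy atoms in the measured pair. Among the compounds with values here, since every value so far sits at the limit (the limit of > 10000 nM in this assay, at which 3 of the 3 values shown sit), the step is expected to be a step that the limit leaves unreadable from compound 3 to compound 4, and compound 4 is estimated at 20000 nM, most likely again a limit.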

Compound 4, half-maximal inhibitory concentration: > 10000 nM
Compound 4 gave a limit, no number; the forecaster's own chance of this, stated with the estimate: 80%; the middle value is on the limit's open side.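

No size can be read for the hydroxy change between compound 3 and compound 4, because both stand at a limit: the limit of > 10000 nM in this assay, at which 4 of the 4 values shown sit.

The compounds shown leave open which change, if any, would give a measurable value in this assay.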